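Cyano for Formyl on a Benzothiophene-Free Description: Compound 4

A few compounds are considered here, and "the series" means these few. Any claim that something is new, unique, unknown or untested is made for them only; others in the source may bear on it.

Measured so far in a functional assay on KB cells (Homo sapiens) for cytotoxicity, tested at 10 uM; on this read-out lower numbers stand for less inhibition and higher numbers for more inhibition at the one concentration tested (going by the name of the read-out):
compound 1, `O=Cc1c(-c2ccccc2)sc2ccccc12`: 42%
compound 2, `COc1ccc(-c2sc3ccccc3c2C=O)cc1`: 89%
compound 3, `O=Cc1c(-c2ccc(Cl)cc2)sc2ccccc12`: 67%

Compound 3 stands second highest of the three numbers in this assay. Its nearest neighbour is compound 2, which gives 89%; the step of a number 22 percentage points lower from compound 2 to compound 3 (beyond the scatter) lies beyond the scatter. Its furthest neighbour is compound 1, which gives 42%; the step of a number 25 percentage points higher from compound 1 to compound 3 (beyond the scatter) also lies beyond the scatter.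

Compound 4 is `N#Cc1c(-c2ccc(Cl)cc2)sc2ccccc12`. The change from compound 3 is cyano in place of formyl on an aromatic carbon.

None of the three measured steps bears on this change. The steps of a number 47 percentage points higher from compound 1 to compound 2 (beyond the scatter) and a number 25 percentage points higher from compound 1 to compound 3 (beyond the scatter) each swap a hydrogen for another group on an aromatic carbon of the pendant ring, and a number 22 percentage points lower from compound 2 to compound 3 (beyond the scatter) swaps methoxy for chloro there; in every case the formyl group is untouched. Going by the values given here, the data therefore hold no step that exchanges formyl for cyano, and no size or direction can be read from them.

Compound 4 is accordingly expected to stay close to compound 3, with the step of a number 7 percentage points lower from compound 3 to compound 4 (within the scatter) estimated as no change beyond the scatter, though with wide uncertainty. The estimate for compound 4 in this assay is 60%, with a range from 30% to 88%.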

Compound 4, a percentage reported as inhibition, at one concentration (the size of the read-out at that concentration, not a potency): 29%
Estimate against measurement, compound 4: 31 percentage points above, and the stated range ends above it.
By their numbers in this assay, from the lowest: compound 4; then compound 1; then compound 3; then compound 2.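

In this assay the exchange of formyl for cyano on the aromatic carbon of the five-membered aromatic ring gives a number 38 percentage points lower from compound 3 to compound 4 (beyond the scatter), a large step, although the two groups have the same count of heavy atoms and of hydrogen-bond acceptors and neither brings a ring or a charge. Going by these compounds alone, the earlier compounds all kept the formyl group and varied only the pendant ring, so this is the first sign that the read-out also responds to the group at this place, and that a carbonyl oxygen and a nitrile nitrogen are not interchangeable there. Nothing in the data explains why the read-out falls with this exchange.

Within the data shown here, it remains open whether the same exchange would lower the read-out to a similar extent with methoxy or hydrogen on the pendant ring, as the step is seen only with chloro there. Also open, on these data alone, is how a carboxylic acid, a primary amide or a hydroxymethyl group at this place would compare with formyl in this assay.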